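A Methylpiperazine Swap on a Weak Antiproliferative Amide

The source may report more compounds than this note shows. Statements on the series, on what has been measured and on what is new or still open speak of the compounds shown alone.

Going by the values given here, in a functional assay on HepG2 cells (Homo sapiens) for antiproliferative activity, read by MTT assay, with a stated time of 48 h (on this read-out lower numbers stand for stronger inhibition and higher numbers for weaker inhibition), compound 2 (`O=C(CN1CCCCC1)Nc1ccc2ncnc(Nc3cccc(Br)c3)c2c1`) gives 16000 nM, the only true number available so far. Compound 1 (`CN1CCN(CC(=O)Nc2ccc3ncnc(Nc4ccc(Cl)cc4)c3c2)CC1`) reads > 100000 nM, which is a limit of the assay and not a number. The next compound to be tested is compound 3 (`CN1CCN(CC(=O)Nc2ccc3ncnc(Nc4cccc(Br)c4)c3c2)CC1`), which keeps the core of compound 2 and carries 4-methylpiperazin-1-yl in place of piperidin-1-yl on a saturated chain carbon bound to a carbonyl carbon. Among the compounds with values here, no measured pair isolates this change, so the forecast is uncertain. The expectation of weaker inhibition rests only on compound 1, which also carries 4-methylpiperazin-1-yl and shows the limit of > 100000 nM. A modest expected loss in this assay is the step of a 1.9-fold higher number from compound 2 to compound 3 (0.27 log units; within the scatter). For compound 3 the estimated value is 30000 nM, with an expected range from 10000 nM to 100000 nM.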

Compound 3, half-maximal inhibitory concentration: 25300 nM
The estimate for compound 3 lay 1.2-fold (0.07 log units) above the measured number; low and high end bracket the measured number.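

In this assay, 4-methylpiperazin-1-yl in place of piperidin-1-yl on a saturated chain carbon bound to a carbonyl carbon gives a 1.6-fold higher number from compound 2 to compound 3 (0.20 log units; within the scatter), so with 3-bromophenyl held constant, compound 2 and compound 3 cannot be told apart at this position. The weak reading of compound 1 therefore does not follow from 4-methylpiperazin-1-yl alone, as 3-bromophenyl in place of 4-chlorophenyl on a nitrogen on an aromatic ring gives an at least 3.9-fold lower number from compound 1 to compound 3 (0.59 log units; beyond the scatter). The reading of compound 1 is a limit of the assay and not a number: the limit of > 100000 nM in this assay, at which 1 of the 3 values shown sits.

Going by these compounds, it remains open how a morpholine ring, a primary amine or a longer chain would read at the saturated chain carbon. Also open, on these data alone, is how a fluorine or a methoxy group on the phenyl ring would compare with the bromine of compound 3.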